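This account rests on a few compounds, and the source may have more. Where it says the series, first, only, none or still open, it means among the compounds named here.

In a functional assay on MCF7 cells (Homo sapiens) for cytotoxicity, read by MTT assay, with a stated time of 4 days (a higher number here means a weaker inhibitor, a lower number a stronger inhibitor), compound 1 `Cc1c(O)ccc2c1[C@H](Cn1cc(-c3ccccn3)nn1)[C@@]13CC(=O)[C@@](C)(CC[C@@H]21)C3` gives > 20000 nM, which is a limit of the assay rather than a number. Compound 2 `Cc1c(O)ccc2c1[C@H](Cn1cc(-c3ccc(C(F)(F)F)cc3)nn1)[C@@]13CC(=O)[C@@](C)(CC[C@@H]21)C3` likewise reaches only the limit > 20000 nM in this assay. The step that the two limits leave unreadable from compound 2 to compound 1 therefore cannot be given a size, and the change it covers is pyridin-2-yl in place of 4-(trifluoromethyl)phenyl on an aromatic carbon. Compound 3 `C=C1C[C@]23C[C@@]1(O)CC[C@H]2c1ccc(OS(=O)(=O)c2ccc(C)cc2)c(C)c1[C@@H]3Cn1cc(-c2ccc(C(F)(F)F)cc2)nn1` in this assay also stops at the limit > 20000 nM. How the core of compound 3 differs from that of compound 2 is not broken down here. Compound 4 `C=C1C[C@]23C[C@@]1(O)CC[C@H]2c1ccc(OS(=O)(=O)c2ccc(C)cc2)c(C)c1[C@@H]3Cn1cc(-c2ccccn2)nn1` has not yet been measured; it stands to compound 3 as compound 1 stands to compound 2, the change being (pyridin-2-yl in place of 4-(trifluoromethyl)phenyl on an aromatic carbon), the same kind of change at a place described in the same words. Because (the limit of > 20000 nM in this assay, at which 3 of the 3 values shown sit), the earlier step offers no readable size to carry over, and all three measured compounds sit at the limit, so compound 4 is expected to stay there as well. Compound 4 is therefore expected to give about 30000 nM in this assay, somewhere between 10000 nM and 100000 nM, which means an expected step that the limit leaves unreadable from compound 3 to compound 4.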

Compound 4, half-maximal inhibitory concentration: > 20000 nM
Compound 4 gave a limit, no number; the forecaster's own chance of this, stated with the estimate: 85%; the middle value lies beyond the limit too.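

Compound 4 gives > 20000 nM in this assay, which is a limit and not a number, so the change from compound 3 to compound 4 has no readable size. The compounds shown leave open whether pyridin-2-yl in place of 4-(trifluoromethyl)phenyl alters the read-out of this assay at all, on either core.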